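This account rests on a few compounds, and the source may have more. Where it says the series, first, only, none or still open, it means among the compounds named here.

In an ADME assay (liver) for metabolic stability, with Liver microsome (Homo sapiens) as the target, using microsomes and NADPH, with a stated time of 30 min, tested at 1 uM; a higher number here means faster removal of the compound, a lower number slower removal:

- Compound 1 `Nc1ccc(S(=O)(=O)N2CCN(c3ncc(C(O)(C(F)(F)F)C(F)(F)F)cc3Br)CC2)cn1`: < 14 mL.min-1.g-1 (a limit)
- Compound 2 `COc1cc(C(O)(C(F)(F)F)C(F)(F)F)cnc1N1CCN(S(=O)(=O)c2ccc(N)nc2)CC1`: < 14 mL.min-1.g-1 (a limit)
- Compound 3 `CS(=O)(=O)c1ccc(-c2cc(C(O)(C(F)(F)F)C(F)(F)F)cnc2N2CCN(S(=O)(=O)c3ccc(N)nc3)CC2)cc1`: 32 mL.min-1.g-1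

For the measured compounds named here, compound 3 holds the only true number in this small set, since the other two compounds stop at the limit of < 14 mL.min-1.g-1 in this assay, at which 2 of the 3 values shown sit. Compound 4 `COc1cncc(-c2cc(C(O)(C(F)(F)F)C(F)(F)F)cnc2N2CCN(S(=O)(=O)c3ccc(N)nc3)CC2)c1` differs from compound 3 by 5-methoxypyridin-3-yl in place of 4-(methylsulfonyl)phenyl on an aromatic carbon. Going by the values given here, two measured steps bear on this: an at least 2.2-fold higher number from compound 1 to compound 3 (0.35 log units; beyond the scatter) and an at least 2.2-fold higher number from compound 2 to compound 3 (0.35 log units; beyond the scatter), both beyond the scatter. Each starts from a bromo or methoxy group, whereas compound 4 keeps a six-membered aromatic ring at that place, so its value should stay near that of compound 3, 32 mL.min-1.g-1. The expected step is a 1.1-fold higher number from compound 3 to compound 4 (0.04 log units; within the scatter), no larger than the scatter. For compound 4 the estimate is 35 mL.min-1.g-1, with an expected range of 15 mL.min-1.g-1 to 80 mL.min-1.g-1.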

Compound 4, intrinsic clearance in microsomes: 44 mL.min-1.g-1
For compound 4 the middle estimate is 1.3-fold (0.10 log units) below the measured one; measured number inside the range.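

In this assay, 5-methoxypyridin-3-yl in place of 4-(methylsulfonyl)phenyl keeps the two compounds within the scatter of each other, a 1.4-fold higher number from compound 3 to compound 4 (0.14 log units; within the scatter). Compound 4 thus shows that compound 3 was not a lone case, since a second aromatic ring of another kind also stands beyond the scatter from the smaller groups, with an at least 3.1-fold higher number from compound 2 to compound 4 (0.49 log units; beyond the scatter) for methoxy and an at least 3.1-fold higher number from compound 1 to compound 4 (0.49 log units; beyond the scatter) for bromo. Compound 1 and compound 2 each give only a limit, not a true number: the limit of < 14 mL.min-1.g-1 in this assay, at which 2 of the 4 values shown sit.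

Going by these compounds, how a non-aromatic group, such as a cyclohexyl ring or a small amine, would read at this place stays open. So does where between bromo and these aromatic rings the faster removal sets in.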